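This account rests on a few compounds, and the source may have more. Where it says the series, first, only, none or still open, it means among the compounds named here.

Measured so far in an assay for inhibition of Fatty-acid amide hydrolase 1 (Rattus norvegicus); a higher number here means a weaker inhibitor, a lower number a stronger inhibitor:

Compound 1 `CCCCCCCC/C=C\CCCCCCCC(=O)c1nnc(-c2cccs2)o1`: compound 1 gives 8 nM
Compound 2 `O=C(CCc1ccc(-c2ccccc2)cc1)c1nnc(-c2ccccn2)o1`: compound 2 gives 0.3 nM

Compound 2 holds the lowest number of the two, and the gap to compound 1 is beyond the scatter. Going by the values given here, no pair differing in a single place has been measured, so no step is known in this assay.

Compound 3 `O=C(O)c1cccc(-c2nnc(C(=O)CCc3ccc(-c4ccccc4)cc3)o2)n1` keeps the whole of compound 2 and differs only by carboxy in place of hydrogen on an aromatic carbon of the six-membered aromatic ring with one nitrogen, next to the ring nitrogen, meta to the large group.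

With no measured step of this kind in the series, the expectation rests on compound 2 alone. Compound 3 is expected to remain a strong inhibitor but to give a somewhat higher number, with the step of a 10-fold higher number from compound 2 to compound 3 (1.00 log units; beyond the scatter) expected to lie beyond the scatter. The estimate for compound 3 is 3 nM, within the range 0.5 nM to 20 nM.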

Compound 3, inhibition constant: 48 nM
Compound 3: middle estimate off by 16-fold (1.20 log units), on the low side; measured number outside the range, above it.
By their numbers in this assay, from the lowest: compound 2; then compound 1; then compound 3.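

In this assay, going by these compounds alone, the change from pyridin-2-yl to 6-carboxypyridin-2-yl gives a 160-fold higher number from compound 2 to compound 3 (2.20 log units; beyond the scatter) and is the only single-place step so far. This position, on an aromatic carbon next to the ring nitrogen and meta to a large group, is therefore far from indifferent to what it carries: hydrogen gives strong inhibition, and carboxy there costs much of it. Nothing measured on these compounds bears on the reason for this loss.

As far as these compounds go, whether the loss belongs to carboxy in particular or to any group at this place stays open; a methyl group, a methyl ester or a primary amide on the same carbon would separate the two. Also open, from the compounds shown here alone, is whether a carboxylic acid on another carbon of this ring gives a step of similar size.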